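Series notes: aromatic ring in place of the cyclic amine

A few compounds are considered here, and "the series" means these few. Any claim that something is new, unique, unknown or untested is made for them only; others in the source may bear on it.

Compound 1 `c1ccc2c(c1)CC(CNCCCNC1=NCCCN1)O2` gives 126 nM in an assay on isolated protein (Bos taurus) with 5-hydroxytryptamine receptor 1D (Homo sapiens) as the target; a higher number here means a weaker inhibitor, a lower number a stronger inhibitor. Compound 2 `c1ccc2c(c1)CCC(CNCCCNC1=NCCN1)O2` gives 6.31 nM in this assay, and compound 3 `c1ccc2c(c1)CCC(CNCCCNC1=NCCCC1)O2` gives 3.98 nM. Compound 3 holds the lowest of the three numbers; its gap to compound 2 lies within the scatter, whereas compound 1 sits beyond it. Among the compounds with values here, the only single-point step in the set, a 1.6-fold lower number from compound 2 to compound 3 (0.20 log units; within the scatter), swaps one ring on the amine nitrogen for another and barely moves the read-out. Compound 4 `c1ccc2c(c1)CCC(CNCCCNc1cnccn1)O2` carries a group of 6 heavy atoms (4 carbon, 2 nitrogen; one six-membered aromatic ring with 2 hetero atoms) in place of a group of 6 heavy atoms (5 carbon, 1 nitrogen; one six-membered non-aromatic ring with 1 hetero atom), on an amine nitrogen. Within the data shown here, no measured step places an aromatic ring at this position, so the small step of a 1.6-fold lower number from compound 2 to compound 3 (0.20 log units; within the scatter) is the sole guide; the step from compound 3 to compound 4 is expected to be modest, a 4.0-fold higher number from compound 3 to compound 4 (0.60 log units; beyond the scatter), leaning toward a higher number. Compound 4 is therefore expected to give 16 nM in this assay, ranging from 4 nM to 63 nM.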

Compound 4, half-maximal inhibitory concentration: 10 nM
The estimate for compound 4 lay 1.6-fold (0.20 log units) above the measured number; low and high end bracket the measured number.
By their numbers in this assay, from the lowest: compounds 3, 2 and 4 (each within the scatter of the next, the first and the last beyond it); then compound 1.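

In this assay, an aromatic ring on this amine nitrogen keeps the number in the range of the non-aromatic rings: pyrazin-2-yl gives a 2.5-fold higher number from compound 3 to compound 4 (0.40 log units; beyond the scatter) and a 1.6-fold higher number from compound 2 to compound 4 (0.20 log units; within the scatter). The position therefore accepts a six-membered aromatic ring with only a modest step from the six-membered non-aromatic ring of compound 3. No measurement at hand accounts for this step.

The compounds shown leave open whether a phenyl or pyridin-2-yl ring at this position would give a similar number, and so whether the two ring nitrogens of pyrazin-2-yl matter.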